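This account rests on a few compounds, and the source may have more. Where it says the series, first, only, none or still open, it means among the compounds named here.

Among the two compounds with a result in an ADME assay on L1210/0 cells (Mus musculus) for cytotoxicity, with a stated time of 48 h (on this read-out higher numbers stand for weaker inhibition and lower numbers for stronger inhibition), compound 1 `O=C(CI)NCc1cn([C@H]2C[C@H](O)[C@@H](CO)O2)c(=O)[nH]c1=O` is the only one that returns an actual number: in this assay compound 1 gives 107000 nM. Compound 2 `O=c1ccn(C[C@@H]2C[C@H](CO)c3ccccc32)c(=O)[nH]1` does not; in this assay compound 2 gives > 200000 nM, which is a limit of the assay and not a number, so the limit of > 200000 nM in this assay, at which 1 of the 2 values shown sits, is where one of the two results sits. Among the measured compounds shown here, no two measured compounds differ in a single place, so no measured step is available to lean on.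

Compound 3 `CCCCC#Cc1cn([C@H]2C[C@H](O)[C@@H](CO)O2)c(=O)[nH]c1=O` has not yet been measured in this assay. Against compound 1 it shows one change, (hex-1-yn-1-yl in place of (((iodomethyl)carbonyl)amino)methyl on an aromatic carbon). For the measured compounds named here, without a measured step of this kind, the expectation rests on the one number and the structural change alone, and for compound 3 the expected step is a 2.1-fold lower number from compound 1 to compound 3 (0.33 log units; beyond the scatter), a modest gain in inhibition beyond the scatter. Compound 3 is accordingly expected to give about 50000 nM in this assay, within a range from 5000 nM to 200000 nM.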

Compound 3, half-maximal inhibitory concentration: > 200000 nM
Compound 3: only a limit was reported; the forecaster's own chance of this, stated with the estimate: 25%; middle value at least 4.0-fold (0.60 log units) away from the limit.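

Hex-1-yn-1-yl in place of (((iodomethyl)carbonyl)amino)methyl on an aromatic carbon gives an at least 1.8-fold higher number from compound 1 to compound 3 (0.27 log units; that floor lies within the scatter) in this assay, the only single-place step available at this position. Compound 3 gives > 200000 nM, which is a limit of the assay and not a number, so only the floor of this step is known and the true size of the change stays unread. With this result, the limit now holds most of the compounds shown: the limit of > 200000 nM in this assay, at which 2 of the 3 values shown sit.

The compounds shown leave open which part of the (((iodomethyl)carbonyl)amino)methyl group goes with the measured number of compound 1. A plain aminomethyl group or an acetylaminomethyl group at this aromatic carbon would separate the amide from the iodine, and a shorter alkyne chain would test the hex-1-yn-1-yl result.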